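A few compounds are considered here, and "the series" means these few. Any claim that something is new, unique, unknown or untested is made for them only; others in the source may bear on it.

Of the compounds shown here, three share a core and have been measured in a physicochemical assay for lipophilicity; a higher number here means a more lipophilic compound, a lower number a more polar compound. Compound 1 `CCCc1cccc2c(C3=C(Br)C(=O)NC3=O)c(-c3ccc(OC)cc3)[nH]c12` gives 3.58 in this assay. Compound 2 `CCCCCCc1ccc2[nH]c(-c3cccc(OC)c3)c(C3=C(Br)C(=O)NC3=O)c2c1` gives 4.26 in this assay. Compound 3 `O=C(CCCc1[nH]c2ccccc2c1C1=C(Br)C(=O)NC1=O)Nc1ccccc1`, the one with the phenylcarbamoyl-bearing chain, gives 2.56 in this assay, the lowest of the three numbers; the nearest of the other two, compound 1, lies higher by a margin beyond the scatter, and compound 2 lies higher still, also beyond the scatter.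

The step to be followed goes from compound 3 to compound 4 `Cc1ccc(NC(=O)CCCc2[nH]c3ccccc3c2C2=C(Br)C(=O)NC2=O)cc1`. The change is methyl in place of hydrogen on an aromatic carbon, which in words is methyl in place of hydrogen on an aromatic carbon, read one bond further out as phenyl to 4-methylphenyl, or phenylcarbamoyl to (4-methylphenyl)carbamoyl. Among the compounds with values here, no step between two measured compounds isolates such a change, so no measured reference exists for it here.

Compound 4 is expected to give 3.06 in this assay, within a range from 2.75 to 3.4. The expected step from compound 3 to compound 4 is a number 0.50 log units higher from compound 3 to compound 4 (beyond the scatter), a modest rise toward the more lipophilic side, somewhat beyond the scatter of repeated measurements.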

Compound 4, partition coefficient: 2.56
For compound 4 the middle estimate is 0.50 log units above the measured one; the whole stated range lies above it.
By their numbers in this assay, from the lowest: compounds 3 and 4 (each within the scatter of the next); then compound 1; then compound 2.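

In this assay, replacing hydrogen with methyl on an aromatic carbon of the six-membered ring, para to a large group, gives no change at the digits printed from compound 3 to compound 4 (within the scatter) and so does not separate the two compounds. Within the data shown here, this pair provides the first reading of a change confined to one place, as the earlier compounds differ from one another in more than one place and their spread of values cannot be assigned to any single group. The reading shows that, on this chain and in this read-out, phenylcarbamoyl and (4-methylphenyl)carbamoyl cannot be told apart, but nothing on hand offers an explanation for that result.

As far as these compounds go, it remains open whether a different group at the same carbon, such as a methoxy group, a chlorine atom, an amine or a carboxylic acid, would shift the value in either direction. From the compounds shown here alone, it is also open whether methyl at another carbon of this ring, or a longer chain in its place, would leave the value just as unchanged.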